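Chloro for fluoro on the aromatic ring of compound 3

This account rests on a few compounds, and the source may have more. Where it says the series, first, only, none or still open, it means among the compounds named here.

Compound 1 `O=C1CC(c2cccc(Br)c2)n2ncnc2N1` gives 84.9 mg/kg in a functional assay on the whole organism (strain Kunming) with Mus musculus as the target; a higher number here means that more compound is needed for the effect, a lower number that less compound is needed. Compound 2 `O=C1CC(c2ccccc2)n2nccc2N1`, on a different core, gives 47.3 mg/kg. Compound 3 `O=C1CC(c2ccccc2F)n2nccc2N1` carries fluoro on the aromatic ring of compound 2; compound 3 gives 47.3 mg/kg; the step of no change at the digits printed from compound 2 to compound 3 (within the scatter) is flat. Compound 3 therefore stands level with compound 2 at the digits shown, the two together the lowest of the three numbers; compound 1 differs from compound 3 only within the scatter, and no single-change step joins compound 1 to either of the others, so its value is read on its own.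

Compound 4 `O=C1CC(c2ccccc2Cl)n2nccc2N1` differs from compound 3 by chloro in place of fluoro on an aromatic carbon. Going by the values given here, the only measured step at this position is the flat one from hydrogen to fluoro, which by itself says little about a move to chloro; compound 1 shows a bromo group on a different ring position and core with no step to compare. Among the compounds with values here, with one flat step and no step in the direction of the larger halogen, the expectation for the step of a 1.0-fold lower number from compound 3 to compound 4 (0.00 log units; within the scatter) is no change beyond the scatter. Compound 4 is estimated at 47 mg/kg, with a range from 24 mg/kg to 95 mg/kg.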

Compound 4, dose for half-maximal effect: 63.4 mg/kg
Estimate against measurement, compound 4: 1.3-fold (0.13 log units) below; the measured number falls inside the stated range.
By their numbers in this assay, from the lowest: compounds 2, 3, 4 and 1 (each within the scatter of the next).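

In this assay, chloro in place of fluoro gives a 1.3-fold higher number from compound 3 to compound 4 (0.13 log units; within the scatter), and chloro in place of hydrogen gives a 1.3-fold higher number from compound 2 to compound 4 (0.13 log units; within the scatter). Hydrogen, fluoro and chloro, on an aromatic carbon of the six-membered aromatic ring of carbon only and ortho to a large group, therefore all read within the scatter of one another, so this position now has two halogens measured rather than one, and neither separates from hydrogen in this assay. No supporting data are available to explain this flat reading at the position.

Still open, going by these compounds, is whether a group of another kind at this place, such as methoxy, an amine or a carboxylic acid, would give a step beyond the scatter, since the three groups compared here are hydrogen and two halogens. Going by these compounds alone, compound 1 differs from each of the other compounds in more than one place, so no step to it can be read, and the effect of its core and of its bromo group remains unresolved.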